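Swapping a small amine for a methylpiperazine on the core

This account rests on a few compounds, and the source may have more. Where it says the series, first, only, none or still open, it means among the compounds named here.

Three compounds share a fused two-ring core carrying an aminomethyl-linked phenyl arm and a second amine on the ring. Compound 1 `O=S(=O)(Nc1ccc(CNc2nc(NC3CC3)nc3ccccc23)cc1)c1ccc(F)cc1` gives 4900 nM in a functional assay on HCT-116 cells (Homo sapiens) for inhibition, read by luminescence and resazurin assay, with a stated time of 3 days; a higher number here means a weaker inhibitor, a lower number a stronger inhibitor. Compound 2 `CCNc1nc(NCc2ccc(C(=O)N[C@H]3C[C@@H]3c3ccccc3)cc2)c2cc(C)ccc2n1` gives 1700 nM in this assay. Compound 3 `O=C(Nc1ccc(F)cc1)c1ccc(CNc2nc(NC3CC3)nc3ccccc23)cc1` gives 2700 nM in this assay; its number lies between those of compound 2 and compound 1, and both gaps are within the scatter of repeated measurements. For the measured compounds named here, the one step that can be traced, a 1.8-fold lower number from compound 1 to compound 3 (0.26 log units; within the scatter), concerns the amide end of the molecule and is also within the scatter.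

Compound 4 `CC1CN(c2nc(NCc3ccc(C(=O)Nc4ccc(F)cc4)cc3)c3ccccc3n2)CCN1` keeps the amide end of compound 3 and changes the other side of the core: 3-methylpiperazin-1-yl in place of cyclopropylamino on an aromatic carbon. Going by the values given here, no measured pair isolates this exchange, so nothing among the measured compounds tells how this assay responds to it; the only traced step sits elsewhere in the molecule and was within the scatter. The expectation for compound 4 is therefore a number near that of compound 3, with a wide range, and the expected step of a 1.2-fold lower number from compound 3 to compound 4 (0.09 log units; within the scatter) is not larger than the scatter. Compound 4 is estimated at 2200 nM, between 600 nM and 8000 nM.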

Compound 4, half-maximal inhibitory concentration: 2800 nM
The estimate for compound 4 lay 1.3-fold (0.10 log units) below the measured number; measured number inside the range.
By their numbers in this assay, from the lowest: compounds 2, 3, 4 and 1 (each within the scatter of the next, the first and the last beyond it).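

In this assay, putting 3-methylpiperazin-1-yl in place of cyclopropylamino on the aromatic carbon between two ring nitrogen atoms gives a 1.0-fold higher number from compound 3 to compound 4 (0.02 log units; within the scatter). For the compounds shown here, this is the first traced change on this side of the core, and it shows that, with this amide end, a six-membered non-aromatic ring with 2 hetero atoms and 7 heavy atoms can replace a group of 4 heavy atoms with a three-membered ring of carbon only, without moving the number beyond the scatter. No measurement offered here explains why the number holds.

This single pair leaves open whether the position is similarly insensitive to other groups, such as a morpholine ring, a plain dimethylamino group or a carboxylic acid on a longer chain, any of which might shift the number well beyond the scatter. It also leaves open whether the same exchange would read alike with the sulfonamide end of compound 1, since the result so far rests on the amide end alone.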